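The source may report more compounds than this note shows. Statements on the series, on what has been measured and on what is new or still open speak of the compounds shown alone.

Compound 1 `COc1ccc(-c2ncnn2-c2cc(OC)c(OC)c(OC)c2)cc1`: 520 nM
Compound 2 `COc1cc(-c2ncnn2-c2ccc(Cl)cc2)cc(OC)c1OC`: > 10000 nM

Among the compounds with values here, in a functional assay on A549 cells (Homo sapiens) for antiproliferative activity, read by MTT assay, with a stated time of 72 h (a higher number here means a weaker inhibitor, a lower number a stronger inhibitor), compound 1 gives 520 nM, the only true number available. Compound 2 gives > 10000 nM, which is a limit of the assay and not a number. Compound 3 `COc1cc(-n2ncnc2-c2cccc(F)c2)cc(OC)c1OC` has 3-fluorophenyl in place of 4-methoxyphenyl on an aromatic carbon of the core of compound 1 (3-fluorophenyl in place of 4-methoxyphenyl on an aromatic carbon). Within the data shown here, no measured step covers this change, so the expectation is tentative: a loss of potency beyond the scatter, an estimated 6.7-fold higher number from compound 1 to compound 3 (0.83 log units; beyond the scatter). The expected value for compound 3 is 3500 nM, with an estimated range of 500 nM to 20000 nM.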

Compound 3, half-maximal inhibitory concentration: > 10000 nM
Compound 3: no number, only a limit; the forecaster's own chance of this, stated with the estimate: 35%; middle value at least 2.8-fold (0.45 log units) from the limit.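

In this assay, within the data shown here, 3-fluorophenyl in place of 4-methoxyphenyl on this aromatic carbon of the core gives an at least 19-fold higher number from compound 1 to compound 3 (1.28 log units; beyond the scatter), the first measured step at this position, and a large one. Activity at this position therefore depends on which aryl group is attached. The step gives only a minimum size, because compound 3 stands at a limit of the assay and not at a number: the limit of > 10000 nM in this assay, at which 2 of the 3 values shown sit.

The compounds shown do not separate the loss of the methoxy group from the entry of the fluorine. Going by these compounds, whether a plain phenyl or a 4-fluorophenyl at this carbon would keep any activity stays open.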